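A Methylcarbamoyl Group in Place of the Carboxy Group

A few compounds are considered here, and "the series" means these few. Any claim that something is new, unique, unknown or untested is made for them only; others in the source may bear on it.

Of the compounds shown here, three share one core and have been tested in an assay on Sf9 cells for inhibition of protein deacetylase HDAC6 (Homo sapiens), read by fluorescence, with a stated time of 40 min, tested at 100 nM; a higher number here means more inhibition at the concentration tested (going by the name of the read-out), a lower number less inhibition. Compound 1 `COc1ccc(-c2nc(CNc3ccc(C(=O)NO)cc3)n(-c3ccccc3)n2)cc1` gives 77.6% in this assay, and compound 2 `O=C(NO)c1ccc(NCc2nc(-c3ccc(Br)cc3)nn2-c2ccccc2)cc1` gives 54.7%. Compound 3 `O=C(O)c1ccc(NCc2nc(-c3ccccc3)nn2-c2ccccc2)cc1`, which carries a carboxy group where the other two carry hydroxamic acids, gives -0.4% in this assay, the lowest of the three numbers, far below both of them.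

Compound 4 `CNC(=O)c1ccc(NCc2nc(-c3ccccc3)nn2-c2ccccc2)cc1` differs from compound 3 in one place: methylamino in place of hydroxy on a carbonyl carbon. Going by the values given here, no measured step bears directly on this change. Among the compounds with values here, the only step measured so far, a number 22.9 percentage points lower from compound 1 to compound 2 (beyond the scatter), concerns a substituent on an aromatic carbon elsewhere in the core and says nothing about the carbonyl carbon that is altered here. What can be said is that the number for compound 3, with its carboxy group, stands well below the numbers for compound 1 and compound 2, which carry hydroxamic acids.

Within the data shown here, with no step to lean on, the expectation for compound 4 is that the methylcarbamoyl group will leave it close to compound 3, so that the expected step of a number 3.4 percentage points higher from compound 3 to compound 4 (within the scatter) is none beyond the scatter. Compound 4 is therefore estimated at 3% in this assay, within a range from -10% to 18%.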

Compound 4, a percentage reported as inhibition, at one concentration (the size of the read-out at that concentration, not a potency): -3.6%
For compound 4 the middle estimate is 6.6 percentage points above the measured one, within the range that was stated.
By their numbers in this assay, from the lowest: compounds 4 and 3 (each within the scatter of the next); then compound 2; then compound 1.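

Going by these compounds alone, the step of a number 3.2 percentage points lower from compound 3 to compound 4 (within the scatter) is the first direct reading of a change on this carbonyl carbon in this assay, and the swap of carboxy for methylcarbamoyl shifts the number by no more than the scatter. Compound 3 gives -0.4% and compound 4 gives -3.6%, so both sit around zero and neither shows measurable inhibition at the concentration tested; the methylamino group therefore does no more here than the hydroxy group it replaces, and a swap between these two groups, with the rest of the molecule unchanged, leaves the read-out where it was. Nothing measured here explains why the number stays at this level.

On these data alone, what a primary carboxamide, a methyl ester or a longer chain on the amide nitrogen would give on this carbonyl carbon stays open, since a read-out that already sits around zero cannot show whether such groups differ from one another. Within the data shown here, also open is the number for a hydroxamic acid on the exact core of compound 3 , the one single-place comparison that would tie the carbonyl group itself to the values of the other compounds.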